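A few compounds are considered here, and "the series" means these few. Any claim that something is new, unique, unknown or untested is made for them only; others in the source may bear on it.

Compound 1, `O=C(CC1CCN(Cc2ccccc2)CC1)c1ccc(CO)cc1`, in an assay on isolated protein for binding affinity to Sigma non-opioid intracellular receptor 1 (Mus musculus) (a lower number here means a stronger inhibitor, a higher number a weaker inhibitor), gives 31 nM.
Compound 2, `Nc1ccc(C(=O)CC2CCN(CC3CC3)CC2)cc1`, in this assay gives 146 nM.
Compound 3, `CSc1ccc(C(O)CC2CCN(Cc3ccccc3)CC2)cc1`, in this assay gives 10 nM.

All three share a piperidine-containing core with a two-carbon link to an aromatic group, and they differ in the substituent on the ring nitrogen, in the linking carbon (carbonyl or alcohol) and in the aromatic group at the far end. Among the three measured numbers compound 3 has the lowest, meaning the strongest binding. Its nearest neighbour is compound 1, whose number is higher by a margin beyond the usual scatter, and compound 2 stands furthest away, far beyond the scatter.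

The next compound, compound 4, `OC(CC1CCN(Cc2ccccc2)CC1)c1cccs1`, has not been measured. It keeps the core and the alcohol carbon of compound 3 and changes only the aromatic group: thiophen-2-yl in place of 4-(methylsulfanyl)phenyl on a saturated chain carbon bound to an oxygen on a saturated carbon and a saturated chain carbon. The ring becomes smaller and the methylsulfanyl substituent is gone, while the count of donors and acceptors stays the same. Within the data shown here, no measured pair in this set isolates such a change, so there is no direct precedent to lean on.

The expectation is a modest loss of affinity, a step from compound 3 to compound 4 of a 2.5-fold higher number from compound 3 to compound 4 (0.40 log units; beyond the scatter) in this assay, somewhat beyond the scatter but not large. Compound 4 is therefore estimated at 25 nM, with a plausible range from 6 nM to 100 nM.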

Compound 4, inhibition constant: 5 nM
Estimate against measurement, compound 4: 5.0-fold (0.70 log units) above, and the stated range ends above it.
By their numbers in this assay, from the lowest: compounds 4 and 3 (each within the scatter of the next); then compound 1; then compound 2.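

Replacing 4-(methylsulfanyl)phenyl with thiophen-2-yl, on a saturated chain carbon bound to an oxygen on a saturated carbon and a saturated chain carbon, gives a 2.0-fold lower number from compound 3 to compound 4 (0.30 log units; within the scatter) in this assay and so leaves the two compounds indistinguishable in binding. Among these compounds, this is the first pair here that differs in only one place, and it shows that this position tolerates a five-membered aromatic ring with 1 hetero atom and 5 heavy atoms as well as a six-membered aromatic ring of carbon carrying a methylsulfanyl group, with 8 heavy atoms in all. Nothing measured here explains why the two groups perform alike.

The compounds shown leave open which feature of the aromatic group matters, a question that plain phenyl, furan-2-yl with oxygen in the ring instead of sulfur, or thiophen-3-yl could each help to answer. They also leave open whether thiophen-2-yl would fare equally well with the carbonyl of compound 1 in place of the alcohol carbon, or with the substituent on the ring nitrogen of compound 2.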